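This account rests on a few compounds, and the source may have more. Where it says the series, first, only, none or still open, it means among the compounds named here.

Series notes on the cytotoxicity read-out.

Compound 1 `Cc1ccc(/C=C/C(=O)O/C(=N/C2CCCCC2)NC2CCCCC2)cc1` and compound 2 `O=C(/C=C/c1ccccc1)O/C(=N/C1CCCCC1)NC1CCCCC1` share one core; compound 3 `COC(=O)c1coc(/C=C/c2ccc(C)cc2)n1` and the unmeasured compound 4 `COC(=O)c1coc(/C=C/c2ccccc2)n1` share another. How the two cores differ is not broken down here. Within each pair the change is the same: hydrogen in place of methyl on an aromatic carbon for the first pair, and hydrogen in place of methyl on an aromatic carbon for the second; the surroundings of the place are described in the same words for both.

In an ADME assay on Vero cells (Chlorocebus sabaeus) for cytotoxicity, read by WST assay, tested at 50 ug/mL (a higher number here means a weaker effect of the compound at the concentration tested, a lower number a stronger effect), compound 1 gives 79.3%. Compound 2 gives 83.9% in this assay, and the step of a number 4.6 percentage points higher from compound 1 to compound 2 (within the scatter) is within the scatter, so the two values are read as the same effect at this concentration. Compound 3 gives 102% in this assay, which stands above both compounds of the first pair by more than the scatter; it shows essentially no effect at the concentration tested.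

For compound 4 the expectation rests on the step of a number 4.6 percentage points higher from compound 1 to compound 2 (within the scatter) made by the same change in the first pair, which is within the scatter. It also rests on compound 3, whose value 102% already sits at the level of no measurable effect. The step of a number 1 percentage points lower from compound 3 to compound 4 (within the scatter) is therefore expected to be small, of the same kind as the earlier one, and to stay within the scatter. Compound 4 is estimated at 101% in this assay, with a range from 88% to 112%.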

Compound 4, a percentage reported as activity, at one concentration (the size of the read-out at that concentration, not a potency): 99.6%
Compound 4: middle estimate off by 1.4 percentage points, on the high side, within the range that was stated.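

In this assay, hydrogen in place of methyl on an aromatic carbon of the six-membered aromatic ring, para to a large group, gives a number 2.4 percentage points lower from compound 3 to compound 4 (within the scatter), so the two values on this core read as the same effect at the concentration tested. Set beside the first pair, the two steps do not differ: the same change on two cores in this assay, a number 4.6 percentage points higher (within the scatter) from compound 1 to compound 2 and a number 2.4 percentage points lower (within the scatter) from compound 3 to compound 4, 7 percentage points apart, within the scatter of two such steps

This shows that, on these two cores, the swap of methyl for hydrogen leaves no readable mark on this read-out; it does not show that a real effect carries from one core to the other, since neither step rises out of the scatter and the agreement is between two null steps at a single concentration, on two cores only.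

Still open, going by these compounds, is whether a different group at this place, such as methoxy, chlorine, an amine or a carboxylic acid, would give a step beyond the scatter on either core, and whether such a step would then match across the two. Also open is what separates the two cores themselves, as no pair shown differs in one place across them, and how these compounds behave in this assay at other concentrations.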